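This account rests on a few compounds, and the source may have more. Where it says the series, first, only, none or still open, it means among the compounds named here.

Measured in a functional assay on BT-549 cells (Homo sapiens) for cytotoxicity, read by sulforhodamine B assay, with a stated time of 48 h, tested at 100 uM; on this read-out higher numbers stand for a weaker effect at the one concentration tested and lower numbers for a stronger effect:
Compound 1, `COc1cc(-c2cc(/C=C/C(=O)c3ccc(Cl)c(Cl)c3)[nH]n2)cc(OC)c1OC`, gives -53%.
Compound 2, `COc1ccc(-c2cc(/C=C/C(=O)c3cc(OC)c(OC)c(OC)c3)[nH]n2)cc1OC`, gives -93%.

Of these two numbers, compound 1 holds the higher one; compound 2 stands well below it, and that gap lies beyond the usual scatter. Compound 3, `COc1cc(-c2cc(/C=C/C(=O)c3ccc(F)c(F)c3)[nH]n2)cc(OC)c1OC`, has not yet been measured. It differs from compound 1 in one place: 3,4-difluorophenyl in place of 3,4-dichlorophenyl on a carbonyl carbon. For the measured compounds named here, no measured pair shows this kind of exchange, so its effect is not known from these data. In this assay the expected step is small, if any, leaning toward a slightly weaker effect: a number 13 percentage points higher from compound 1 to compound 3 (beyond the scatter). Compound 3 is therefore estimated at -40%, within a range from -75% to -5%.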

Compound 3, a percentage reported as activity, at one concentration (the size of the read-out at that concentration, not a potency): -58%
Estimate against measurement, compound 3: 18 percentage points above, and the stated range covers the measured number.
By their numbers in this assay, from the lowest: compound 2; then compounds 3 and 1 (each within the scatter of the next).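

In this assay, placing 3,4-difluorophenyl in place of 3,4-dichlorophenyl on the carbonyl carbon gives a number 5 percentage points lower from compound 1 to compound 3 (within the scatter). This is the first step shown at this position, and it means that the read-out does not separate these two dihalogenated phenyl groups on the core of compound 1. No measured property is available that bears on this result.

As far as these compounds go, whether a phenyl group carrying an amine or a carboxylic acid would give a similar number on this carbonyl carbon remains open. So does what a plain phenyl group would give there, and with it whether the halogens matter at all.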